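Swapping the Aryl Group on the Cinnamide Analogue

The source may report more compounds than this note shows. Statements on the series, on what has been measured and on what is new or still open speak of the compounds shown alone.

In a functional assay on NCI-H460 cells (Homo sapiens) for antiproliferative activity, read by CCK-8 assay, with a stated time of 72 h, tested at 2 uM (a higher number here means a stronger effect of the compound at the concentration tested, a lower number a weaker effect), compound 1 `Cc1ccc(Nc2nc(Cl)nc3c2ncn3Cc2ccc(C(=O)Nc3ccccc3N)cc2)cc1` gives 67.3%, compound 2 `Cc1ccc(Nc2nc(Cl)nc3c2ncn3Cc2ccc(/C=C/C(=O)Nc3ccccc3N)cc2)cc1` gives 31.3%, and compound 3 `Nc1ccccc1NC(=O)c1ccc(Cn2cnc3c(NCc4ccccc4)nc(Cl)nc32)cc1` gives 44.7%. Compound 2 thus stands lowest of the three, with compound 3 nearest and compound 1 furthest from it. Two steps connect these compounds: a number 36 percentage points lower from compound 1 to compound 2 (beyond the scatter), and a number 22.6 percentage points lower from compound 1 to compound 3 (beyond the scatter).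

Compound 4 `Nc1ccccc1NC(=O)/C=C/c1ccc(Cn2cnc3c(Nc4cccc(OC(F)(F)F)c4)nc(Cl)nc32)cc1` differs from compound 2 in a single place: 3-(trifluoromethoxy)phenyl in place of 4-methylphenyl on a nitrogen on an aromatic ring. Within the data shown here, the step from compound 1 to compound 3 is the only measured change at this same nitrogen, and there the loss was modest; the step from compound 1 to compound 2 concerns a different part of the molecule. Nothing measured here contains the 3-(trifluoromethoxy)phenyl group, so the direction of this change cannot be read from the data. The expected step is a number 0.7 percentage points higher from compound 2 to compound 4 (within the scatter), that is, no change beyond the scatter. Compound 4 is therefore estimated at 32%, with a likely range from 15% to 52%.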

Compound 4, a percentage reported as inhibition, at one concentration (the size of the read-out at that concentration, not a potency): 2.1%
Compound 4: the middle estimate sits 29.9 percentage points above what was measured; the measured number lies below the stated range.
By their numbers in this assay, from the lowest: compound 4; then compound 2; then compound 3; then compound 1.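

With the ethenyl link in place, the group on this nitrogen still counts: in this assay, 3-(trifluoromethoxy)phenyl in place of 4-methylphenyl gives a number 29.2 percentage points lower from compound 2 to compound 4 (beyond the scatter). Among these compounds, the only earlier change at this nitrogen swapped the ring for benzyl, whereas this one keeps an aromatic ring directly on the nitrogen, so having such a ring there does not by itself preserve the effect. No measurement shown explains the drop.

Going by these compounds, it remains open whether the loss comes from the trifluoromethoxy group itself or from its place on the ring, a question that 3-methoxyphenyl or 4-(trifluoromethoxy)phenyl on this nitrogen could help settle. Also open, on these data alone, is whether the same swap would cost as much on compound 1, which lacks the ethenyl link.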